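Swapping the alkyne-linked azole for a pyridine

A few compounds are considered here, and "the series" means these few. Any claim that something is new, unique, unknown or untested is made for them only; others in the source may bear on it.

Compound 2 `Cn1ccnc1C#Cc1cc(Cl)ccc1OCC(=O)O` is the weakest of the three measured compounds in an assay on CHO cells for displacement of a labelled ligand from prostaglandin D2 receptor 2 (Homo sapiens), read by scintillation counting (on this read-out higher numbers stand for weaker inhibition and lower numbers for stronger inhibition), where compound 2 gives 1470 nM. Compound 1 `CCCS(=O)(=O)c1cccc(C#Cc2cc(Cl)ccc2OCC(=O)O)c1` gives 9 nM in this assay, and compound 3 `CCCS(=O)(=O)c1ccc(F)c(C#Cc2cc(Cl)ccc2OC(C)C(=O)O)c1` gives 3 nM, both far lower numbers than compound 2 shows. Compound 4 `O=C(O)COc1ccc(Cl)cc1C#Cc1cccnc1` differs from compound 2 in one place: pyridin-3-yl in place of 1-methyl-1H-imidazol-2-yl on a triple-bonded carbon. Going by the values given here, no pair of measured compounds differs in just this way, so the step has to be judged from the spread of the three values. A step towards lower numbers, beyond the scatter, is expected, with the estimated change from compound 2 to compound 4 being a 4.9-fold lower number from compound 2 to compound 4 (0.69 log units; beyond the scatter). The expected value for compound 4 in this assay is 300 nM, within a range from 70 nM to 1200 nM.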

Compound 4, inhibition constant: 117 nM
For compound 4 the middle estimate is 2.6-fold (0.41 log units) above the measured one; low and high end bracket the measured number.
By their numbers in this assay, from the lowest: compound 3; then compound 1; then compound 4; then compound 2.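

On a triple-bonded carbon of the shared core, pyridin-3-yl in place of 1-methyl-1H-imidazol-2-yl gives a 13-fold lower number from compound 2 to compound 4 (1.10 log units; beyond the scatter) in this assay and so is a large step. The earlier compounds shown here differed in more than one place, whereas this pair shows that changing this ring alone moves the number well beyond the scatter. Nothing measured here bears on why the step has this size.

Open, going by these compounds, is how an unsubstituted phenyl ring at this place would compare with pyridin-3-yl, and whether the same change would give a similar step on the core of compound 3.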